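Nitro in Place of Hydrogen: From Compound 1 to Compound 3

The source may report more compounds than this note shows. Statements on the series, on what has been measured and on what is new or still open speak of the compounds shown alone.

Compound 1 `CSc1nc(NCCCCNc2ccnc3cc(Cl)ccc23)c(C#N)c(-c2ccccc2)n1` is the more tolerated of two compounds tested in an ADME assay on Vero cells (Chlorocebus sabaeus) for cytotoxicity, read by microscopy (a lower number here means that less compound is tolerated, a higher number that more compound is tolerated), where compound 1 gives 20000 nM. Its companion compound 2 `CSc1nc(OCCCNc2ccnc3cc(Cl)ccc23)c(C#N)c(-c2ccccc2)n1` gives 4000 nM, a lower number that lies beyond the usual scatter of this kind of measurement. Compound 3 `CSc1nc(NCCCCNc2ccnc3cc(Cl)ccc23)c(C#N)c(-c2ccc([N+](=O)[O-])cc2)n1` has not yet been measured; it differs from compound 1 in one place (nitro in place of hydrogen on an aromatic carbon). Going by the values given here, nothing measured so far shows what such a change does in this assay; the step of a 1.3-fold lower number from compound 1 to compound 3 (0.12 log units; within the scatter) is expected to stay small, within the scatter. Compound 3 is therefore estimated at 15000 nM, between 5000 nM and 40000 nM.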

Compound 3, minimum cytotoxic concentration: 4000 nM
Compound 3: middle estimate off by 3.8-fold (0.57 log units), on the high side; the whole stated range lies above it.
By their numbers in this assay, from the lowest: compounds 2 and 3 (each within the scatter of the next); then compound 1.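

In this assay, going from phenyl to 4-nitrophenyl gives a 5.0-fold lower number from compound 1 to compound 3 (0.70 log units; beyond the scatter), so this aromatic carbon, para to a large group, is a place where a single added group can change how much compound the cells tolerate. The earlier compounds shown here showed nothing about this position. What lies behind the step remains unexplained by anything at hand. From the compounds shown here alone, whether an amine or a carboxylic acid on the same carbon would lower the number as well stays open. So does whether nitro would give a similar step on compound 2.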